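Adding isobutyl to compound 2

The source may report more compounds than this note shows. Statements on the series, on what has been measured and on what is new or still open speak of the compounds shown alone.

In a physicochemical assay for solubility, in phosphate buffer, measured as kinetic solubility, at pH 7.4 (on this read-out higher numbers stand for higher solubility and lower numbers for lower solubility), compound 2 (`Cc1ccccc1-c1nc(CN2CCC(C(=O)NCCCN3CCCCC3)CC2)c(C)o1`) gives > 65 ug/mL, which is a limit and not a number. No measured number places it any more exactly, and the other two compounds measured also give only limits. Compound 4 (`Cc1ccccc1-c1nc(CN2CCC(C(=O)NCCCN3CCCC(CC(C)C)C3)CC2)c(C)o1`) differs from compound 2 by isobutyl in place of hydrogen on a saturated ring carbon.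

For the measured compounds named here, no measured step covers this change. Going by the values given here, the only step available is a step that the two limits leave unreadable from compound 1 to compound 3, and it concerns a different place in the molecule, so it offers no size to carry over. The nearest guidance comes from compound 1 (`Cc1oc(-c2ccccc2Cl)nc1CN1CCC(C(=O)NCCCN2C[C@H](C)C[C@H](C)C2)CC1`), which bears methyl groups on a six-membered non-aromatic ring with 1 nitrogen and gives > 72 ug/mL, a limit. Compound 3 (`Cc1oc(-c2c(F)cccc2F)nc1CN1CCC(C(=O)NCCCN2C[C@H](C)C[C@H](C)C2)CC1`) bears the same methyl groups and gives > 72 ug/mL, also a limit. These two results suggest that alkyl groups on that ring need not bring a large fall in this assay, although neither compound carries a group as large as isobutyl. The expected change is therefore a modest fall or none beyond the scatter, and the estimated step is an at least 1.0-fold lower number from compound 2 to compound 4 (0.03 log units; that floor lies within the scatter). For compound 4 the expected value is 60 ug/mL, with an estimated range from 25 ug/mL to 75 ug/mL.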

Compound 4, solubility: 54.9 ug/mL
Estimate against measurement, compound 4: 1.1-fold (0.04 log units) above; the range from low to high includes it.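

Compound 1 and compound 3, which bear only methyl groups on their six-membered ring, end in limits. Compound 4, with isobutyl on a saturated ring carbon two ring bonds from the ring nitrogen, gives an actual number in this assay: 54.9 ug/mL. Set against its hydrogen-bearing counterpart, this change gives an at least 1.1-fold lower number from compound 2 to compound 4 (0.07 log units; that floor lies within the scatter). Only that floor can be stated, because compound 2 stands at a limit: the limit of > 65 ug/mL in this assay, at which 1 of the 4 values shown sits.

The true size of the isobutyl change therefore stays open, and the one other step among the compounds shown, from compound 1 to compound 3, cannot be read. Also open, as far as these compounds go, is what a hydroxyl group, an amine or a longer chain on the same saturated ring carbon would give in this assay, and whether isobutyl would give a comparable step on the 2-chlorophenyl or 2,6-difluorophenyl compounds.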